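Octyl-type phosphate series: shortening the chain on compound 1

The source may report more compounds than this note shows. Statements on the series, on what has been measured and on what is new or still open speak of the compounds shown alone.

Measured in a functional assay on MDA-MB-231 cells (Homo sapiens) for inhibition, read by MTT assay, with stated times of 18 h and 4 h; a lower number here means a stronger inhibitor, a higher number a weaker inhibitor:
- compound 1 `CCCCCCCCOP(=O)(O)OCCSC(=S)N1CCCC1`: 69000 nM
- compound 2 `CCCCCCCCOP(=O)(O)OCCSC(=S)N1CCN(C)CC1`: 58500 nM
- compound 3 `CCCCCCCCOP(=O)(O)OCCSC(=S)N1CCCCCC1`: 27000 nM

Compound 1 stands at the upper end of these numbers. The steps away from it are a 1.2-fold lower number from compound 1 to compound 2 (0.07 log units; within the scatter) and a 2.6-fold lower number from compound 1 to compound 3 (0.41 log units; beyond the scatter). The remaining measured step is a 2.2-fold lower number from compound 2 to compound 3 (0.34 log units; beyond the scatter).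

Compound 4 `CCCOP(=O)(O)OCCSC(=S)N1CCCC1` keeps the group on the thiocarbonyl carbon of compound 1 and changes the chain instead. The difference is hydrogen in place of pentyl on a saturated chain carbon, three bonds along the chain from an oxygen on an unsaturated carbon.

All three measured steps swap the group on the thiocarbonyl carbon, and none touches the chain, so none measures this change directly. They serve only as a gauge of how far the series has moved so far. The direction is therefore a judgement with no measured support: a higher number is expected in this assay, and the size is expected to be similar to a 2.6-fold lower number from compound 1 to compound 3 (0.41 log units; beyond the scatter), in the opposite direction. The expected step is a 2.3-fold higher number from compound 1 to compound 4 (0.37 log units; beyond the scatter). For compound 4 the estimate is 160000 nM, with an expected range of 70000 nM to 400000 nM.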

Compound 4, half-maximal inhibitory concentration: 67000 nM
For compound 4 the middle estimate is 2.4-fold (0.38 log units) above the measured one; measured number outside the range, below it.
By their numbers in this assay, from the lowest: compound 3; then compounds 2, 4 and 1 (each within the scatter of the next).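

Removing pentyl at this place on the chain, with pyrrolidin-1-yl held fixed, gives a 1.0-fold lower number from compound 1 to compound 4 (0.01 log units; within the scatter) in this assay, so compound 1 and compound 4 cannot be told apart in this assay. Within the data shown here, the earlier steps all swapped the group on the thiocarbonyl carbon, and among them a 2.6-fold lower number from compound 1 to compound 3 (0.41 log units; beyond the scatter) remains the one step away from compound 1 that lies beyond the scatter; this pair adds the only reading on the chain, and for this pair the pentyl portion makes no difference that the assay can resolve. Nothing available bears on why the pair reads alike.

On these data alone, the chain change is read only with pyrrolidin-1-yl, so it remains open whether removing pentyl would also leave the number unmoved with azepan-1-yl, the group of compound 3. Also open, as far as these compounds go, is how the assay responds to a chain longer than that of compound 1, such as dodecyl, or to a chain carrying an amine or a carboxylic acid.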